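Swapping Chloro for Bromo on Two Related Cores

The source may hold more compounds than are shown below. What is called first, only, known or untested is meant among the compounds shown, and "the series" means these compounds.

Compound 1 `Clc1ccccc1CSc1nnc(-c2cnccn2)o1` and compound 2 `Brc1ccccc1CSc1nnc(-c2cnccn2)o1` share one core and differ in a single place: bromo in place of chloro on an aromatic carbon. In a functional assay on HepG2 cells (Homo sapiens) for antiproliferative activity, read by MTT assay, with a stated time of 48 h (on this read-out lower numbers stand for stronger inhibition and higher numbers for weaker inhibition), compound 1 gives 12300 nM, while compound 2 gives 4220 nM, a step of a 2.9-fold lower number from compound 1 to compound 2 (0.46 log units; beyond the scatter). Compound 3 `Clc1cccc(CSc2nnc(-c3cnccn3)n2-c2ccccc2)c1` has a different core; how it differs from compound 1 is not broken down here. In this assay compound 3 gives 19600 nM. Compound 4 `Brc1cccc(CSc2nnc(-c3cnccn3)n2-c2ccccc2)c1` differs from compound 3 by bromo in place of chloro on an aromatic carbon. This is the same kind of change as in the measured pair, but the halogen sits ortho to a large group in compound 1 and meta to a large group in compound 3, on another core. A step toward a lower number is expected from compound 3 to compound 4, a 2.1-fold lower number from compound 3 to compound 4 (0.31 log units; beyond the scatter), smaller than the earlier one because a 2.9-fold lower number from compound 1 to compound 2 (0.46 log units; beyond the scatter) arose on a different core and place. Compound 4 is estimated at 9500 nM, within 3500 nM to 25000 nM.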

Compound 4, half-maximal inhibitory concentration: 10600 nM
The estimate for compound 4 lay 1.1-fold (0.05 log units) below the measured number; low and high end bracket the measured number.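

The new step is a 1.8-fold lower number from compound 3 to compound 4 (0.27 log units; within the scatter), so taken alone it is no clear change in this assay. Set beside the earlier step, the swap from chloro to bromo gives steps that cannot be told apart on the two cores: the same change on two cores in this assay, a 2.9-fold lower number (0.46 log units; beyond the scatter) from compound 1 to compound 2 and a 1.8-fold lower number (0.27 log units; within the scatter) from compound 3 to compound 4, 1.6-fold (0.20 log units) apart, within the scatter of two such steps. Going by these compounds alone, this fits the change carrying over from one core to the other, but it does not prove a fixed effect: there is only one pair per core, and the halogen also sits in a different place on each, so the roles of core and place stay unseparated.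

The compounds shown leave open whether other groups in place of the halogen, such as methyl, methoxy or an amine, would follow the same course. They also leave open how chloro and bromo compare at one and the same place on both cores.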